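Ring chloro at the phenoxy: cytotoxicity series notes

This account rests on a few compounds, and the source may have more. Where it says the series, first, only, none or still open, it means among the compounds named here.

Measured so far in an ADME assay on PBMC cells (Homo sapiens) for cytotoxicity; a lower number here means that less compound is tolerated, a higher number that more compound is tolerated:
- compound 1 `CC(CCNC(=O)c1c(Cl)cncc1Cl)N1CCC(C(Oc2ccccc2)c2ccc(C(F)(F)F)cc2)CC1`: 6800 nM
- compound 2 `CCO/N=C(/c1ccc(Br)cc1)C1CCN(C(CC)CCNC(=O)c2c(C)cc[n+]([O-])c2C)CC1`: reaches only the limit of the assay at > 177000 nM
- compound 3 `CC(CCNC(=O)c1c(Cl)cncc1Cl)N1CCC(C(Oc2ccccc2)c2ccc(Br)cc2)CC1`: 31700 nM

Compound 1 has the lowest of the two numbers in this assay; the nearest is compound 3, with a 4.7-fold higher number from compound 1 to compound 3 (0.67 log units; beyond the scatter), a step that swaps the substituent on the benzylic aryl ring. Compound 2 stands at the limit of the assay the limit of > 177000 nM in this assay, at which 1 of the 3 values shown sits, and gives no number.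

Compound 4 `CC(CCNC(=O)c1c(Cl)cncc1Cl)N1CCC(C(Oc2ccccc2Cl)c2ccc(C(F)(F)F)cc2)CC1` differs from compound 1 by chloro in place of hydrogen on an aromatic carbon. Going by the values given here, no measured step touches the phenoxy ring; the one step on record, from compound 1 to compound 3, acts at a different site and is modest. A chloro entering where a hydrogen leaves is a small addition, so for compound 4 no step beyond the scatter in this assay is expected, if anything a slight rise: compound 4 is expected to give 9000 nM (range 3500 nM to 25000 nM), i.e. an expected step of a 1.3-fold higher number from compound 1 to compound 4 (0.12 log units; within the scatter).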

Compound 4, half-maximal cytotoxic concentration: 4400 nM
For compound 4 the middle estimate is 2.0-fold (0.31 log units) above the measured one, and the stated range covers the measured number.
By their numbers in this assay, from the lowest: compounds 4 and 1 (each within the scatter of the next); then compound 3. At a limit, above all of these: compound 2.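

Phenoxy ring, first reading: in this assay, 2-chlorophenoxy in place of phenoxy gives a 1.5-fold lower number from compound 1 to compound 4 (0.19 log units; within the scatter) and so leaves this position with no change that can be told from the scatter. A chloro entering on this ring thus differs from the bromo for trifluoromethyl swap, which gives a 4.7-fold higher number from compound 1 to compound 3 (0.67 log units; beyond the scatter) and lies beyond the scatter. Nothing in the available evidence bears on this step.

Going by these compounds, whether a methoxy group or an amine at the same place on the phenoxy ring would stay within the scatter remains open. Also open, on these data alone, is whether the chloro reads the same with bromo in place of trifluoromethyl, as in compound 3.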